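The source may hold more compounds than are shown below. What is called first, only, known or untested is meant among the compounds shown, and "the series" means these compounds.

Three compounds have so far been measured in a functional assay on the whole organism (plasma, strain Sprague-Dawley) with Rattus norvegicus as the target, with a stated time of 2 h, at a dose of 100 mg/kg by the oral route; a lower number here means a weaker effect, a higher number a stronger effect of the compound at the dose given:

Compound 1, `c1ccc(C(/N=C2\CCCCCCN2)C2CC2)cc1`: 58%
Compound 2, `c1ccc(C(/N=C2\CCCCCN2)C2CCCCC2)cc1`: 0%
Compound 3, `c1ccc(C(/N=C2\CCCCN2)c2cccs2)cc1`: 32%

Among these three numbers, compound 2 stands lowest. The nearest to it is compound 3, and the gap between the two lies beyond the usual scatter of this kind of measurement; the furthest is compound 1, whose gap from compound 2 is also beyond the scatter. Compound 2 is therefore the weakest of the three at the dose used. The three compounds differ from one another in more than one place, so no single change can be read off between any pair of them.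

The next compound, compound 4, `c1ccc(C(/N=C2\CCCCCN2)c2cccs2)cc1`, differs from compound 2 in one place only: thiophen-2-yl in place of cyclohexyl on a saturated chain carbon bound to an aromatic carbon and a double-bonded nitrogen. For the measured compounds named here, no measured pair shows this exact change, so its effect has to be judged from the compounds at hand. Compound 3 also carries thiophen-2-yl at this place and gives 32%, which points toward a rise. Compound 4 is expected to give 30%, within a range from 5% to 60%. The step this estimate means, a number 30 percentage points higher from compound 2 to compound 4 (beyond the scatter), is expected to be a rise beyond the usual scatter.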

Compound 4, a percentage reported as inhibition, in the whole organism at one dose (the size of the read-out at that dose, not a potency): 50%
Compound 4: the middle estimate sits 20 percentage points below what was measured; low and high end bracket the measured number.
By their numbers in this assay, from the lowest: compound 2; then compound 3; then compounds 4 and 1 (each within the scatter of the next).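

In this assay, putting thiophen-2-yl in place of cyclohexyl on the saturated chain carbon bound to an aromatic carbon and a double-bonded nitrogen gives a number 50 percentage points higher from compound 2 to compound 4 (beyond the scatter) and leaves the rest of the structure untouched. For the compounds shown here, this is the first direct evidence that the group at this one place can strongly change the read-out at the dose given, though this is a size of effect at one dose and not a potency. Nothing available here explains the rise.

The two groups differ in several ways at once, in ring size, in being aromatic or not, and in carrying sulfur, so a single pair cannot show which of these differences matters; cyclopentyl, phenyl or furan-2-yl at the same place would help to separate them. Going by these compounds, it also remains open whether the same exchange would give a similar step on a different core, such as the core of compound 1, which here carries cyclopropyl at this place.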